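The source may report more compounds than this note shows. Statements on the series, on what has been measured and on what is new or still open speak of the compounds shown alone.

Of the compounds shown here, three of one shared core have been measured in an assay on Sf9 cells for inhibition of prolyl hydroxylase EGLN2 (Homo sapiens), read by TR-FRET, with stated times of 30 min and 2 h; on this read-out lower numbers stand for stronger inhibition and higher numbers for weaker inhibition. Compound 1 `O=C(O)CNC(=O)c1c(O)c2c(n(Cc3ccc(C(F)(F)F)cc3)c1=O)CCOC2` gives 14 nM. Compound 2 `O=C(O)CNC(=O)c1c(O)c2c(n(Cc3ccc(F)cc3F)c1=O)COC2` gives 2.2 nM. Compound 3 `O=C(O)CNC(=O)c1c(O)c2c(n(Cc3ccc(C(F)(F)F)nc3)c1=O)COC2` gives 3.6 nM. Compound 2 has the lowest of the three numbers; its number and that of compound 3 lie within the scatter of each other, while the number of compound 1 lies beyond the scatter above it, so compound 2 cannot be called stronger than compound 3 on these data.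

The step to compound 4 `O=C(O)CNC(=O)c1c(O)c2c(n(Cc3nc(C(F)(F)F)cs3)c1=O)COC2` changes only the group on the chain carbon: 4-(trifluoromethyl)-1,3-thiazol-2-yl in place of 2,4-difluorophenyl on a saturated chain carbon bound to an aromatic nitrogen. Going by the values given here, no pair of measured compounds shows this exact change, so the expected size of the step rests on the whole set. Compound 3, which also carries a trifluoromethyl-bearing aromatic ring on the same core, gives 3.6 nM, close to compound 2. The step is therefore expected to be small, at most a slight rise not clearly beyond the scatter, as a 2.3-fold higher number from compound 2 to compound 4 (0.36 log units; beyond the scatter). For compound 4 the estimate in this assay is 5 nM, with a range from 1.5 nM to 15 nM.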

Compound 4, half-maximal inhibitory concentration: 3.7 nM
Compound 4: middle estimate off by 1.4-fold (0.13 log units), on the high side; the range from low to high includes it.
By their numbers in this assay, from the lowest: compounds 2, 3 and 4 (each within the scatter of the next); then compound 1.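

Putting 4-(trifluoromethyl)-1,3-thiazol-2-yl in place of 2,4-difluorophenyl on a saturated chain carbon bound to an aromatic nitrogen gives a 1.7-fold higher number from compound 2 to compound 4 (0.23 log units; within the scatter) in this assay and so leaves the two numbers indistinguishable. On this pair, a five-membered aromatic ring with 2 hetero atoms can stand where a six-membered aromatic ring of carbon only stood, and going from 0 to 2 hydrogen-bond acceptors in the group brings no step beyond the scatter. Nothing available explains why these two groups give such similar numbers. The compounds shown leave open whether this position also tolerates a group without an aromatic ring, such as cyclohexyl, or one carrying an amine or a carboxylic acid. They also leave open how 4-(trifluoromethyl)-1,3-thiazol-2-yl behaves on the core of compound 1.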